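A 2-chloro substituent on the pyridine amide of compound 1

The source may hold more compounds than are shown below. What is called first, only, known or untested is meant among the compounds shown, and "the series" means these compounds.

Measured so far in a functional assay on MDA-MB-231 cells (Homo sapiens) for antiproliferative activity, read by MTT assay, with stated times of 72 h and 4 h; on this read-out lower numbers stand for stronger inhibition and higher numbers for weaker inhibition:
- compound 1 `O=C(Nc1ccc(Cl)c(-c2nnc3c(Cl)cccn23)c1)c1cccnc1`: > 100000 nM, a limit of the assay
- compound 2 `O=C(Nc1ccc(Cl)c(-c2nnc3c(Cl)cccn23)c1)c1ccc(C(F)(F)F)cc1F`: > 100000 nM, a limit of the assay
- compound 3 `CS(=O)(=O)c1ccc(C(=O)Nc2ccc(Cl)c(-c3nnc4c(Cl)cccn34)c2)c(Cl)c1`: 37200 nM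

Compound 1 sits at the limit of this assay, so no number is known for it. Compound 2 sits at the same limit. Compound 3 is the only one of the three with a numerical value in this assay, and the limit of > 100000 nM in this assay, at which 2 of the 3 values shown sit, shows where the other two stand relative to it.

Compound 4 `O=C(Nc1ccc(Cl)c(-c2nnc3c(Cl)cccn23)c1)c1cccnc1Cl` differs from compound 1 by chloro in place of hydrogen on an aromatic carbon, next to the ring nitrogen and ortho to a large group. Going by the values given here, no step between measured compounds separates out this change, and compound 1 itself gives only a limit, so no size or direction can be read from the data; any step from compound 1 to compound 4 in this assay is therefore uncertain, and an outcome still at the limit is as plausible as a modest gain.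

The value expected for compound 4 in this assay is 90000 nM, with a range from 30000 nM to 300000 nM, which means an expected step of an at least 1.1-fold lower number from compound 1 to compound 4 (0.04 log units; that floor lies within the scatter).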

Compound 4, half-maximal inhibitory concentration: 89700 nM
Beside the measured number, compound 4's estimate is 1.0-fold (0.00 log units) above it; low and high end bracket the measured number.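

In this assay compound 1 gives > 100000 nM, which is a limit of the assay and not a number. With chloro in place of hydrogen on an aromatic carbon, next to the ring nitrogen and ortho to a large group, the 2-chloropyridin-3-yl amide gives a measured number, and the change reads as an at least 1.1-fold lower number from compound 1 to compound 4 (0.04 log units; that floor lies within the scatter). That floor lies within the scatter, and the true size of the step stays unknown because one end of it is only a limit: the limit of > 100000 nM in this assay, at which 2 of the 4 values shown sit.

The compounds shown leave open whether a methyl, a methoxy or an amine on the same carbon would also give a number in this assay. They also leave open whether a fluoro or a bromo there would give a value different from that of the chloro in compound 4.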